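From ethyl to methoxy on a shared core

The source may report more compounds than this note shows. Statements on the series, on what has been measured and on what is new or still open speak of the compounds shown alone.

Of the compounds shown here, two built on a shared core have been measured so far in a functional assay on MDA-MB-435 cells (Homo sapiens) for inhibition, read by sulforhodamine B assay, with a stated time of 48 h; a higher number here means that more compound is needed for the effect, a lower number that less compound is needed. In this test, compound 1 (`CCCN(c1ccc(OC)cc1)c1ncnc2occ(C)c12`) gives 27.3 nM. Compound 2 (`CCc1ccc(N(C)c2ncnc3occ(C)c23)cc1`) gives 183 nM, the higher of the two numbers, and the gap between them lies beyond the usual scatter.

Compound 3 (`COc1ccc(N(C)c2ncnc3occ(C)c23)cc1`) departs from compound 2 in a single place: methoxy in place of ethyl on an aromatic carbon. Methoxy stands in place of ethyl on an aromatic carbon, para to a large group. Among the compounds with values here, no measured pair yet isolates a change in one place, so the evidence for any forecast is thin. Compound 1 also carries a methoxy group and reads 27.3 nM, although it differs from compound 2 in more than one place. On that single hint, compound 3 is expected to give a lower number than compound 2 in this assay, by a step beyond the scatter. The expected change is an 8.3-fold lower number from compound 2 to compound 3 (0.92 log units; beyond the scatter). The estimated value for compound 3 is 22 nM, with an expected range from 6 nM to 80 nM.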

Compound 3, half-maximal effective concentration: 4.3 nM
Compound 3: middle estimate off by 5.1-fold (0.71 log units), on the high side; measured number below the stated range.
By their numbers in this assay, from the lowest: compound 3; then compound 1; then compound 2.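

Within the data shown here, with the first pair that differs in one place, the exchange of ethyl for methoxy on an aromatic carbon, para to a large group, turns out to matter greatly in this assay: the result is a 43-fold lower number from compound 2 to compound 3 (1.63 log units; beyond the scatter). The two groups count the same number of heavy atoms, and the entering methoxy brings one hydrogen-bond acceptor where ethyl brings none, so this position responds strongly to a swap that leaves the heavy-atom count unchanged. A second single change, hydrogen in place of ethyl on a saturated chain carbon bound to a nitrogen on an aromatic ring, with methoxy kept on the aromatic carbon, gives a 6.3-fold lower number from compound 1 to compound 3 (0.80 log units; beyond the scatter), a modest step beside the first.

From the compounds shown here alone, how a hydroxyl group, a chlorine atom or an ethoxy group on the same aromatic carbon would compare with methoxy stays open, as does whether the change on the chain would give a similar step with ethyl on the aromatic carbon. Nothing measured here explains why either step has the size it has.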